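The source may hold more compounds than are shown below. What is called first, only, known or untested is meant among the compounds shown, and "the series" means these compounds.

Measured compounds:
compound 1 `CCCCOC(=O)OCC(CO)CCn1cnc2cnc(N)nc21`: 696 h
compound 2 `CCCCCOC(=O)OCC(CO)CCn1cnc2cnc(N)nc21`: 600 h
compound 3 `COC(=O)OCC(CO)CCn1cnc2cnc(N)nc21`: 552 h

All three numbers come from an ADME assay for pharmacokinetics, read by HPLC, at 37 degrees C, at pH 1.2; a higher number here means that the compound lasts longer, a lower number that the compound disappears faster. The three values lie close together: compound 3 sits alongside compound 2 and compound 1, and none of the gaps between them reaches beyond the scatter, so no order among the three can be read from these numbers.

The next compound is compound 4 `CCCOC(=O)OCC(CO)CCn1cnc2cnc(N)nc21`. Against compound 3 the change is ethyl in place of hydrogen on a saturated chain carbon bound to an oxygen next to a carbonyl group. Among the compounds with values here, two measured steps bear on this place on the chain: a 1.3-fold lower number from compound 1 to compound 3 (0.10 log units; within the scatter) and a 1.1-fold lower number from compound 2 to compound 3 (0.04 log units; within the scatter). Both steps, which remove a longer chain from this carbon, stayed within the scatter, and the step of a 1.2-fold lower number from compound 1 to compound 2 (0.06 log units; within the scatter) along the chain also stayed within it. Adding an ethyl group at the same carbon is therefore expected to give no step beyond the scatter in this assay, in either direction.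

Compound 4 is expected to give 610 h in this assay, with a range from 400 h to 900 h; the expected step is a 1.1-fold higher number from compound 3 to compound 4 (0.04 log units; within the scatter).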

Compound 4, half-life in the ADME assay: 696 h
Compound 4: middle estimate off by 1.1-fold (0.06 log units), on the low side, and the stated range covers the measured number.
By their numbers in the ADME assay, from the lowest: compounds 3, 2, 1 and 4 (each within the scatter of the next).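

In the ADME assay the propoxycarbonyl compound falls in with the others, a 1.3-fold higher number from compound 3 to compound 4 (0.10 log units; within the scatter), a 1.2-fold higher number from compound 2 to compound 4 (0.06 log units; within the scatter) and no change at the digits printed from compound 1 to compound 4 (within the scatter), so chain length at this carbon still gives no readable order in half-life. In a physicochemical assay for solubility, read by spectrophotometry, at 20 degrees C (on this read-out higher numbers stand for higher solubility and lower numbers for lower solubility), compound 3 gives 14100 ug/mL and compound 4 gives 68000 ug/mL. Ethyl in place of hydrogen on this saturated chain carbon therefore gives the first step beyond the scatter at this position, in solubility and not in half-life: the measured solubility of compound 3, 14100 ug/mL, and of compound 4, 68000 ug/mL, a 4.8-fold higher number (0.68 log units; beyond the scatter)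

The compounds shown leave open how solubility runs along the chain at this carbon beyond these two compounds. They also leave open whether a branched chain such as isopropyl, or a phenyl ring, at this carbon would keep half-life as level as the straight chains do.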